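From furan-3-yl to 1-benzofuran-2-yl with methylamino retained

The compounds below may be only part of what the source reports. "The series", "measured", "known", "first", "only" and "open" are said of these compounds alone.

In a functional assay on CCRF-CEM cells (Homo sapiens), read by MTT assay, with a stated time of 72 h (a lower number here means a stronger inhibitor, a higher number a weaker inhibitor), compound 1 (`C#Cc1cn([C@@H]2O[C@H](CO)[C@@H](O)[C@H]2O)c2ncnc(OC)c12`) reads > 20000 nM and this is a limit of the assay, not a number. Compound 2 (`CSc1ncnc2c1c(-c1ccoc1)cn2[C@@H]1O[C@H](CO)[C@@H](O)[C@H]1O`) gives a measured value (14200 nM). Compound 3 (`CNc1ncnc2c1c(-c1ccoc1)cn2[C@@H]1O[C@H](CO)[C@@H](O)[C@H]1O`) reads > 20000 nM and this too is only a limit. Compound 3 therefore has no number of its own and stands with most of the series at one limit (the limit of > 20000 nM in this assay, at which 2 of the 3 values shown sit).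

Compound 4 (`CNc1ncnc2c1c(-c1cc3ccccc3o1)cn2[C@@H]1O[C@H](CO)[C@@H](O)[C@H]1O`) keeps the methylamino group of compound 3 and takes 1-benzofuran-2-yl in place of furan-3-yl on an aromatic carbon. Going by the values given here, the only measured step (an at least 1.4-fold higher number from compound 2 to compound 3 (0.14 log units; that floor lies within the scatter)) exchanges methylsulfanyl for methylamino, so it gives no size for this change, and no measured step alters the furan-3-yl group. Among the compounds with values here, no step clearly beyond the scatter is therefore expected in this assay, and a second limit reading is quite possible. The estimated step is an at least 1.2-fold lower number from compound 3 to compound 4 (0.09 log units; that floor lies within the scatter) (an expectation only). The expected value for compound 4 is 16000 nM (estimated range 6000 nM to 20000 nM).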

Compound 4, half-maximal inhibitory concentration: > 20000 nM
Compound 4 was reported as a limit; the forecaster's own chance of this, stated with the estimate: 60%; middle value at least 1.2-fold (0.09 log units) away from the limit.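

Compound 3 and compound 4 both read as limits in this assay, not as numbers, so no step can be read between them: the limit of > 20000 nM in this assay, at which 3 of the 4 values shown sit.

The compounds shown leave open whether 1-benzofuran-2-yl in place of furan-3-yl changes the reading at all, and in which direction.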